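Extending the Iodophenyl Sulfonate Amide Chain

The compounds below may be only part of what the source reports. "The series", "measured", "known", "first", "only" and "open" are said of these compounds alone.

Compound 3 `CC(C)C(=O)Nc1ccc(S(=O)(=O)Oc2ccccc2I)cc1` gives 13000 nM in a functional assay on M21 cells (Homo sapiens) for antiproliferative activity, read by sulforhodamine B assay, with a stated time of 48 h (on this read-out lower numbers stand for stronger inhibition and higher numbers for weaker inhibition), the second highest of three numbers. Its nearest neighbour is compound 2 `CC(C)C(=O)Nc1ccc(S(=O)(=O)Oc2ccccc2C(C)C)cc1`, which gives 11000 nM; the step of a 1.2-fold higher number from compound 2 to compound 3 (0.07 log units; within the scatter) lies within the scatter. Compound 1 `CCCC(=O)Nc1cccc(S(=O)(=O)Oc2ccccc2C(C)C)c1` gives 20000 nM, also within the scatter of compound 3. Compound 4 `O=C(CCCCl)Nc1ccc(S(=O)(=O)Oc2ccccc2I)cc1` differs from compound 3 by 3-chloropropyl in place of isopropyl on a carbonyl carbon. Within the data shown here, no measured step bears on this position: the only one, a 1.2-fold higher number from compound 2 to compound 3 (0.07 log units; within the scatter), concerns a substituent on an aromatic carbon, and all three values lie within the scatter of one another. The expected step in this assay is therefore none beyond the scatter, written as no change at the digits printed from compound 3 to compound 4 (within the scatter). Compound 4 is estimated at 13000 nM, with a range from 5000 nM to 35000 nM.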

Compound 4, half-maximal inhibitory concentration: 7200 nM
Beside the measured number, compound 4's estimate is 1.8-fold (0.26 log units) above it; low and high end bracket the measured number.
By their numbers in this assay, from the lowest: compounds 4, 2, 3 and 1 (each within the scatter of the next, the first and the last beyond it).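

In this assay, among these compounds, the first step at the carbonyl carbon, a 1.8-fold lower number from compound 3 to compound 4 (0.26 log units; within the scatter), replaces isopropyl with 3-chloropropyl. This position therefore accepts the chlorine-bearing chain, with the amide and the rest of compound 3 unchanged, without a shift beyond the scatter. Nothing measured here bears on the step or explains it.

The compounds shown leave open whether a butyl chain without the chlorine would give a similar number, and whether an amine or a carboxylic acid at the end of the chain would move it beyond the scatter.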